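The compounds below may be only part of what the source reports. "The series", "measured", "known", "first", "only" and "open" are said of these compounds alone.

Compound 1 (`N/N=C1\C[C@@H](c2ccc(O)cc2)Oc2cc(O)cc(O)c21`) and compound 2 (`Cn1cccc1/C=N/N=C1\C[C@@H](c2ccc(O)cc2)Oc2cc(O)cc(O)c21`) share one core. In a functional assay on L5178Y cells (Mus musculus) for inhibition, read by MTT assay, with a stated time of 24 h (a lower number here means a stronger inhibitor, a higher number a weaker inhibitor), compound 1 gives >= 11300 nM as a limit of the assay and not a number. Compound 2 gives >= 11300 nM in this assay and this is again a limit, so compound 2 has no number of its own to stand on. Among the measured compounds shown here, the one measured step is a step that the two limits leave unreadable from compound 1 to compound 2 and it offers no size to carry forward. The evidence so far amounts to the limit of >= 11300 nM in this assay, at which 2 of the 2 values shown sit, and nothing more.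

Compound 3 (`O=C(N/N=C1\C[C@@H](c2ccc(O)cc2)Oc2cc(O)cc(O)c21)c1ccco1`) is the next to be read. The change is a group of 8 heavy atoms (5 carbon, 1 nitrogen, 2 oxygen; one five-membered aromatic ring with 1 hetero atom) in place of a group of 8 heavy atoms (6 carbon, 2 nitrogen; one five-membered aromatic ring with 1 hetero atom), on a double-bonded nitrogen on a double-bonded nitrogen, with ((furan-2-yl)carbonyl)amino entering. Compound 2 offers only its limit >= 11300 nM as a starting point, so no step beyond the scatter is expected in this assay and no direction can be argued. The expected step is a step that the limit leaves unreadable from compound 2 to compound 3 and it remains an estimate only. For compound 3 the expected value is 12000 nM with an estimated range of 4000 nM to 30000 nM and a report at the limit is the likelier outcome.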

Compound 3, half-maximal inhibitory concentration: >= 11300 nM
Compound 3 gave a limit, no number; the forecaster's own chance of this, stated with the estimate: 65%; the middle value lies beyond the limit too.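

Among the compounds shown here, compound 1, compound 2 and compound 3 each give only a limit and not a number in this assay, so no step among the three can be read. Left open is whether any group on the double-bonded nitrogen of the shared core gives a measurable value in this assay, since the record so far is only this: the limit of >= 11300 nM in this assay, at which 3 of the 3 values shown sit.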